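Replacing the Propylsulfonyl Ring in a Gut Hormone Receptor Agonist

This account rests on a few compounds, and the source may have more. Where it says the series, first, only, none or still open, it means among the compounds named here.

Among the measured compounds shown here, compound 3 `CCCc1cnc(N2CCC(C3Cc4cc(C5=CCN(S(=O)(=O)CCC)CC5)ccc4O3)CC2)nc1` gives 82 nM in a functional assay on HEK293 cells for agonist activity at Glucose-dependent insulinotropic receptor (Homo sapiens), read by cAMP accumulation, with a stated time of 60 min (a lower number here means that less compound is needed, a higher number that more compound is needed for the effect), the second highest of the three numbers known. Compound 2 `CCCS(=O)(=O)N1CC=C(c2ccc3c(c2)CC(C2CCN(C(=O)OC4CCCCC4)CC2)O3)CC1` gives 51 nM, and compound 1 `CCCS(=O)(=O)N1CC=C(c2ccc3c(c2)CC(C2CCN(S(=O)(=O)CCC)CC2)O3)CC1` gives 1000 nM. The measured steps of a 20-fold lower number from compound 1 to compound 2 (1.29 log units; beyond the scatter), a 12-fold lower number from compound 1 to compound 3 (1.09 log units; beyond the scatter) and a 1.6-fold higher number from compound 2 to compound 3 (0.21 log units; within the scatter) all change the group on the amine nitrogen in a ring. Compound 4 `CCCc1cnc(N2CCC(C3Cc4cc(-c5ccc(S(C)(=O)=O)cc5F)ccc4O3)CC2)nc1` instead alters the other end of the shared core: a group of 11 heavy atoms (7 carbon, 2 oxygen, 1 fluorine, 1 sulfur; one six-membered aromatic ring of carbon only) in place of a group of 12 heavy atoms (8 carbon, 1 nitrogen, 2 oxygen, 1 sulfur; one six-membered non-aromatic ring with 1 hetero atom), on an aromatic carbon. For the measured compounds named here, no measured step touches that position, so the direction of the change is unknown; the expectation can only start from compound 3 and its value of 82 nM. Compound 4 is therefore estimated at 150 nM, between 25 nM and 900 nM. The step expected is a 1.8-fold higher number from compound 3 to compound 4 (0.26 log units; within the scatter), with wide uncertainty either way.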

Compound 4, half-maximal effective concentration: 541 nM
Beside the measured number, compound 4's estimate is 3.6-fold (0.56 log units) below it, within the range that was stated.
By their numbers in this assay, from the lowest: compounds 2 and 3 (each within the scatter of the next); then compounds 4 and 1 (each within the scatter of the next).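

In this assay, the step to 2-fluoro-4-(methylsulfonyl)phenyl gives a 6.6-fold higher number from compound 3 to compound 4 (0.82 log units; beyond the scatter), the first sign that this aromatic carbon, at the end of the shared core that earlier steps left unchanged, also affects the number. Nothing measured here explains the shift. This single step changes the ring, the fluorine and the sulfonyl substituent together, and the compounds shown cannot separate their contributions. Open too, from the compounds shown here alone, are how a 4-(methylsulfonyl)phenyl group without the fluorine would compare and whether the step would match with cyclohexyloxycarbonyl on the ring nitrogen.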